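The source may report more compounds than this note shows. Statements on the series, on what has been measured and on what is new or still open speak of the compounds shown alone.

Working notes on the series. Three compounds have a measurement in a physicochemical assay for solubility, read by spectrophotometry, in phosphate buffer, with a stated time of 2 h, at pH 7.4 (on this read-out lower numbers stand for lower solubility and higher numbers for higher solubility), so far. Compound 1, `O=C(c1cc2cc(C3CC3)ccc2[nH]1)N1CC(=O)N(Cc2ccccc2)[C@@H](CN2CCN(Cc3ccccc3)CC2)C1`, gives 12900 nM in this assay. Compound 2, `COc1ccc2[nH]c(C(=O)N3CC(=O)N(Cc4ccoc4)[C@@H](Cc4ccccc4)C3)cc2c1`, gives 63600 nM in this assay. Compound 3, `COc1ccc2[nH]c(C(=O)N3CC(=O)N(Cc4ccccc4)[C@@H](COc4ccc(F)cc4)C3)cc2c1`, gives 17500 nM in this assay. Among these three numbers compound 3 stands second highest: its nearest neighbour is compound 1, whose number lies within the scatter of it, so no order between compound 1 and compound 3 can be claimed; its furthest neighbour is compound 2, whose number lies beyond the scatter above it. Within the data shown here, no pair among the measured compounds differs in a single place, so no measured step is available to guide the next compound.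

Compound 4, `COc1ccc2[nH]c(C(=O)N3CC(=O)N(Cc4ccccc4)[C@@H](CN4CCc5ccccc5C4)C3)cc2c1`, is not yet measured in this assay. It differs from compound 3 in one place: 1,2,3,4-tetrahydroisoquinolin-2-yl in place of 4-fluorophenoxy on a saturated chain carbon bound to a saturated ring carbon. Among the measured compounds shown here, with no single-change step among the measured compounds, the expectation rests on compound 3 alone, whose value is 17500 nM, and on the change itself.

The step expected from compound 3 to compound 4 in this assay is a 1.4-fold higher number from compound 3 to compound 4 (0.15 log units; within the scatter), a small upward move that may well not exceed the scatter. Compound 4 is therefore estimated at 25000 nM in this assay, with a range from 8000 nM to 80000 nM.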

Compound 4, solubility: 9000 nM
Beside the measured number, compound 4's estimate is 2.8-fold (0.44 log units) above it; the measured number falls inside the stated range.
By their numbers in this assay, from the lowest: compounds 4, 1 and 3 (each within the scatter of the next); then compound 2.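

In this assay, among these compounds, the exchange of 4-fluorophenoxy for 1,2,3,4-tetrahydroisoquinolin-2-yl on a saturated chain carbon bound to a saturated ring carbon gives a 1.9-fold lower number from compound 3 to compound 4 (0.29 log units; within the scatter) and is the first single-change step. The step stays within the scatter, so compound 3 and compound 4 cannot be ordered, even though the entering group has more heavy atoms, a ring nitrogen in place of the ether oxygen, and a second ring; both groups count one six-membered aromatic ring of carbon only, no hydrogen-bond donors, one hydrogen-bond acceptor and no net charge. No measurement shown accounts for the result, and this single step offers no explanation of it.

What the compounds leave open is whether any group at this place gives a step beyond the scatter, for example a morpholin-4-yl, a carboxylic acid or a group without an aromatic ring. Also open, on these data alone, is whether the same exchange gives a similar step with another group on the shared core, such as furan-3-ylmethyl in place of the benzyl group.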